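Caco-2 permeability: from pyridin-4-yl to pyridinylethynyl

The compounds below may be only part of what the source reports. "The series", "measured", "known", "first", "only" and "open" are said of these compounds alone.

- compound 1 `CNC(=O)[C@@H](NC(=O)[C@@](O)(CCCN(Cc1ccc(-c2ccccc2)cc1)NC(=O)[C@@H](NC(=O)OC)C(C)(C)C)Cc1ccccc1)C(C)(C)C` gives 21 10^-6 cm/s in an ADME assay on Caco-2 cells (Homo sapiens) for permeability, in the apical to basolateral direction, with a stated time of 60 min, tested at 10 uM; a lower number here means that the compound crosses the layer more slowly, a higher number that the compound crosses the layer faster
- compound 2 `CNC(=O)[C@@H](NC(=O)[C@@](O)(CCCN(Cc1ccc(-c2ccncc2)cc1)NC(=O)[C@@H](NC(=O)OC)C(C)(C)C)Cc1ccccc1)C(C)(C)C` gives 1.9 10^-6 cm/s in this assay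

For the measured compounds named here, compound 2 holds the lower of the two numbers, and the only measured step is an 11-fold lower number from compound 1 to compound 2 (1.04 log units; beyond the scatter), a large one beyond the scatter. Compound 3 `CNC(=O)[C@@H](NC(=O)[C@@](O)(CCCN(Cc1ccc(C#Cc2cccnc2)cc1)NC(=O)[C@@H](NC(=O)OC)C(C)(C)C)Cc1ccccc1)C(C)(C)C` has not yet been measured and keeps the rest of compound 2 unchanged. The difference is 2-(pyridin-3-yl)ethynyl in place of pyridin-4-yl on an aromatic carbon, para to a large group.

Going by the values given here, the one measured step bears only indirectly, since it exchanged phenyl for pyridin-4-yl, while here a six-membered aromatic ring with one hetero atom stands on both sides of the change. Among the compounds with values here, no measured compound shows what a triple bond does. The expectation therefore starts from compound 2 at 1.9 10^-6 cm/s and not from compound 1 at 21 10^-6 cm/s, with no step beyond the scatter foreseen. The expected step is a 1.6-fold higher number from compound 2 to compound 3 (0.20 log units; within the scatter), slightly upward but poorly constrained. In this assay the estimate for compound 3 is 3 10^-6 cm/s, with an expected range of 0.8 10^-6 cm/s to 10 10^-6 cm/s as the working figure.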

Compound 3, apparent permeability: 6.1 10^-6 cm/s
Beside the measured number, compound 3's estimate is 2.0-fold (0.31 log units) below it; low and high end bracket the measured number.
By their numbers in this assay, from the lowest: compound 2; then compound 3; then compound 1.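

Placed on an aromatic carbon para to a large group, 2-(pyridin-3-yl)ethynyl in place of pyridin-4-yl gives a 3.2-fold higher number from compound 2 to compound 3 (0.51 log units; beyond the scatter) in this assay, so the number at this position is not set by the presence of a six-membered aromatic ring with one hetero atom alone: both groups carry such a ring and the same count of hydrogen-bond acceptors, with no net charge, yet the step lies beyond the scatter. Set against the phenyl group of compound 1, the same group still leaves a 3.4-fold lower number from compound 1 to compound 3 (0.54 log units; beyond the scatter), so the ethynyl-linked pyridine does not reach the number of the all-carbon ring. With every step among the three beyond the scatter, compound 3 stands clearly between compound 2 and compound 1, and this position gives graded rather than all-or-nothing changes across these three groups.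

Compound 3 changes the triple bond and the pyridin-3-yl attachment together, and a 2-(pyridin-4-yl)ethynyl or 2-phenylethynyl group at this position would be needed to separate the two, while an amine or a carboxylic acid on the terminal ring remains an open case. No accompanying measurement explains any of these steps.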